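A few compounds are considered here, and "the series" means these few. Any claim that something is new, unique, unknown or untested is made for them only; others in the source may bear on it.

Compound 1, `CCS(=O)(=O)Nc1ccc(NC(=O)c2cccc(C(F)(F)F)c2)cc1C`, 114000 nM; compound 2, `CCS(=O)(=O)Nc1ccc(NC(=O)c2cccc(C(F)(F)F)c2)cc1OC`, 84800 nM; compound 3, `CS(=O)(=O)Nc1ccc(NC(=O)c2cccc(C(F)(F)F)c2)cc1Cl`, > 250000 nM.

Of the compounds shown here, three sharing one core have been measured in an ADME assay on RAW264.7 cells (Mus musculus) for cytotoxicity, read by MTT assay, with a stated time of 48 h; a lower number here means a stronger inhibitor, a higher number a weaker inhibitor. Compound 1 gives 114000 nM in this assay. Compound 2 gives 84800 nM in this assay, and the step of a 1.3-fold lower number from compound 1 to compound 2 (0.13 log units; within the scatter) is too small to read as a change. For compound 3 the assay reports only a limit, > 250000 nM, at which (the limit of > 250000 nM in this assay, at which 1 of the 3 values shown sits); no number is known for it.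

Compound 4, `CCS(=O)(=O)Nc1ccc(NC(=O)c2cccc(C(F)(F)F)c2)cc1Cl`, has not been measured. It differs from compound 3 in one place: methyl in place of hydrogen on a saturated chain carbon bound to a sulfonyl sulfur. Neither measured step touches this position. Within the data shown here, the only measured step, from compound 1 to compound 2, concerns a substituent on the aromatic ring and lies within the scatter, so it gives no guidance on the size or direction of the change from compound 3 to compound 4. Compounds 1 and 2, which carry the ethylsulfonyl group, both give numbers rather than limits, and compound 3 stands at a limit.

Compound 4 is therefore expected to give 150000 nM, within 60000 nM to 300000 nM, in this assay. The step of an at least 1.6-fold lower number from compound 3 to compound 4 (0.22 log units; that floor lies within the scatter) is only an estimate, and a limit is a real possibility for compound 4.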

Compound 4, half-maximal inhibitory concentration: 62400 nM
For compound 4 the middle estimate is 2.4-fold (0.38 log units) above the measured one; the measured number falls inside the stated range.
By their numbers in this assay, from the lowest: compounds 4, 2 and 1 (each within the scatter of the next). At a limit, above all of these: compound 3.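

Compound 3 stands at a limit, so until now nothing could be said about this position. The change from methylsulfonyl to ethylsulfonyl, with the chloro kept, gives an at least 4.0-fold lower number from compound 3 to compound 4 (0.60 log units; beyond the scatter) in this assay, the first step among these compounds that lies beyond the scatter. That step is a floor and not a size, since the value of compound 3 is only a limit: the limit of > 250000 nM in this assay, at which 1 of the 4 values shown sits. The substituent on the aromatic carbon, by contrast, cannot be read as a change among the ethylsulfonyl compounds: chloro in place of methoxy gives a 1.4-fold lower number from compound 2 to compound 4 (0.13 log units; within the scatter), and chloro in place of methyl gives a 1.8-fold lower number from compound 1 to compound 4 (0.26 log units; within the scatter).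

The compounds shown leave open whether a longer chain on the sulfonyl sulfur, such as propyl, would continue in the same direction, and what an amine or a carboxylic acid at the end of that chain would give. Among these compounds, they also leave open whether the step from methylsulfonyl to ethylsulfonyl holds with methyl or methoxy on the aromatic carbon, as the one pair that shows it carries chloro.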